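Removing the propanoyl group from compound 3

The source may hold more compounds than are shown below. What is called first, only, known or untested is meant among the compounds shown, and "the series" means these compounds.

Compound 3 `CCC(=O)N1c2ccccc2CCC1C(=O)Nc1cc(C(F)(F)F)cc(C(F)(F)F)c1` carries the lowest of the two numbers shown; in a functional assay on NCI-H23 cells (Homo sapiens) for cytotoxicity, read by sulforhodamine B assay, with a stated time of 72 h (on this read-out lower numbers stand for stronger inhibition of growth and higher numbers for weaker inhibition of growth), compound 3 gives 7820 nM. Its nearest neighbour is compound 2 `CCCC(=O)N1c2ccccc2CCC1C(=O)Nc1cc(C(F)(F)F)cc(C(F)(F)F)c1`, which in this assay gives 15000 nM; the step of a 1.9-fold lower number from compound 2 to compound 3 (0.28 log units; within the scatter) lies within the scatter, so no order between these two is claimed. Compound 1 `CC(=O)N1c2ccccc2CCC1C(=O)Nc1cc(C(F)(F)F)cc(C(F)(F)F)c1` gives only a limit in this assay, > 70000 nM. Both steps away from that limit are beyond the scatter: an at least 4.6-fold lower number from compound 1 to compound 2 (0.66 log units; beyond the scatter) and an at least 8.9-fold lower number from compound 1 to compound 3 (0.95 log units; beyond the scatter).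

Compound 4 `O=C(Nc1cc(C(F)(F)F)cc(C(F)(F)F)c1)C1CCc2ccccc2N1` differs from compound 3 by hydrogen in place of propanoyl on a nitrogen on an aromatic ring in a ring. Among the compounds with values here, the steps that bear on this change are the two from compound 1, where the shortest acyl group gave the weakest result, and the step of a 1.9-fold lower number from compound 2 to compound 3 (0.28 log units; within the scatter), where the two longer acyl groups did not separate. Taking the acyl group away altogether is expected to move the number back up, with a fair chance that only a limit is reported. Compound 4 is therefore estimated at 40000 nM, in a range from 10000 nM to 100000 nM, which means an expected step of a 5.1-fold higher number from compound 3 to compound 4 (0.71 log units; beyond the scatter).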

Compound 4, concentration for 50% growth inhibition: 8410 nM
Beside the measured number, compound 4's estimate is 4.8-fold (0.68 log units) above it, outside the stated range (below it).
By their numbers in this assay, from the lowest: compounds 3, 4 and 2 (each within the scatter of the next). At a limit, above all of these: compound 1.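

In this assay, taking the acyl group away entirely does not weaken growth inhibition, as the free ring nitrogen of compound 4 cannot be told apart from its acylated neighbours (a 1.1-fold higher number from compound 3 to compound 4 (0.03 log units; within the scatter); a 1.8-fold lower number from compound 2 to compound 4 (0.25 log units; within the scatter)). Compound 4 also gives a clearly lower number than the acetyl compound (an at least 8.3-fold lower number from compound 1 to compound 4 (0.92 log units; beyond the scatter)), so among these compounds an acyl group on this nitrogen is not needed for this level of activity, and acetyl alone stands apart from the rest. Compound 1 is reported only as a limit: the limit of > 70000 nM in this assay, at which 1 of the 4 values shown sits.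

The compounds shown leave open whether any group on this nitrogen can take the number clearly past the level shared by compounds 2, 3 and 4. A longer chain such as hexanoyl, a benzoyl or a simple methyl could test this.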